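The source may hold more compounds than are shown below. What is called first, only, known or untested is meant among the compounds shown, and "the series" means these compounds.

Compound 1 `COC(C)(C)CCCC(C)C/C=C/C(C)=C/C(=O)OC1CCCC1` gives 7.01 in a physicochemical assay for lipophilicity; on this read-out higher numbers stand for higher lipophilicity and lower numbers for lower lipophilicity.
Compound 2 `CC(=O)OC(C)(C)CCCC(C)C/C=C/C(C)=C/C(=O)OC(C)C` gives 5.98 in this assay.

Compound 1 has the higher of these two numbers; compound 2 sits lower by a gap that is beyond the usual scatter, so the order is real. Compound 3 `CCC(C)C(=O)/C=C(C)/C=C/CC(C)CCCC(C)(C)OC` has not been measured. It differs from compound 1 in one place: sec-butyl in place of cyclopentyloxy on a carbonyl carbon. Going by the values given here, no measured pair in this set shows such a change, so the size of the step is a guess. In this assay compound 3 is expected to come out somewhat lower than compound 1, a step of a number 0.61 log units lower from compound 1 to compound 3 (beyond the scatter). Compound 3 is therefore estimated at 6.4, within a range of 5.9 to 6.9.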

Compound 3, partition coefficient: 6.02
Compound 3: middle estimate off by 0.38 log units, on the high side; low and high end bracket the measured number.
By their numbers in this assay, from the lowest: compounds 2 and 3 (each within the scatter of the next); then compound 1.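

Going by these compounds alone, on the carbonyl carbon, sec-butyl in place of cyclopentyloxy gives the first single-place change that can be read in this assay, with a number 0.99 log units lower from compound 1 to compound 3 (beyond the scatter), a step beyond the usual scatter. The change removes the ring and the hydrogen-bond acceptor of cyclopentyloxy together, so this one pair cannot separate the two. From the compounds shown here alone, what cyclopentyl or an amine on that carbonyl carbon would give remains open. The data shown offer no measured explanation for this step.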